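This account rests on a few compounds, and the source may have more. Where it says the series, first, only, none or still open, it means among the compounds named here.

Measured compounds:
compound 1 `CCCS(=O)(=O)N1CCN(C2(CNC(=O)c3ccccc3OC(F)(F)F)CCCCC2)CC1` gives 22 nM in an assay on JAR cells for inhibition of sodium- and chloride-dependent glycine transporter 1 (Homo sapiens), read by scintillation proximity assay; on this read-out higher numbers stand for weaker inhibition and lower numbers for stronger inhibition;
compound 2 `CCCS(=O)(=O)N1CCN(C2(CNC(=O)c3ccc(F)cc3C)CCCCC2)CC1` gives 28.1 nM in this assay.

Compound 2 sits alongside compound 1 on these two numbers: the step of a 1.3-fold higher number from compound 1 to compound 2 (0.11 log units; within the scatter) is within the scatter, so the two compounds cannot be told apart in this assay. Compound 3 `CCCS(=O)(=O)N1CCN(C2(CNC(=O)c3c(Cl)cccc3Cl)CCCCC2)CC1` differs from compound 2 by 2,6-dichlorophenyl in place of 4-fluoro-2-methylphenyl on a carbonyl carbon. Going by the values given here, only one measured step bears on this position, the swap of the aryl group on the carbonyl carbon from compound 1 to compound 2, and it left the number where it was. The data hold nothing on a 2,6-dichlorophenyl group at this place, so the step of a 1.2-fold higher number from compound 2 to compound 3 (0.10 log units; within the scatter) is expected to be small, with no direction beyond the scatter to be claimed. For compound 3 the expected value in this assay is 35 nM, with a range from 12 nM to 110 nM.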

Compound 3, half-maximal inhibitory concentration: 12.8 nM
Beside the measured number, compound 3's estimate is 2.7-fold (0.44 log units) above it, within the range that was stated.
By their numbers in this assay, from the lowest: compounds 3, 1 and 2 (each within the scatter of the next, the first and the last beyond it).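

Going by these compounds alone, the aryl group on the carbonyl carbon can move the number in this assay: 2,6-dichlorophenyl in place of 4-fluoro-2-methylphenyl gives a 2.2-fold lower number from compound 2 to compound 3 (0.34 log units; beyond the scatter) and is the first step at this position to clear the scatter, though only modestly. Set against 2-(trifluoromethoxy)phenyl, the same group gives a 1.7-fold lower number from compound 1 to compound 3 (0.24 log units; within the scatter) and so does not separate compound 3 from compound 1, which leaves the difference standing against compound 2 alone. No measurement at hand accounts for the difference between these aryl groups.

Whether both chlorines are needed stays open, since the compounds shown include neither a plain phenyl nor a 2-chlorophenyl group on this carbonyl carbon. Also open, as far as these compounds go, is how the number would respond to a pyridine ring here, or to an amine or a carboxylic acid on the aryl group.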